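Removing the chloro group from compound 1

A few compounds are considered here, and "the series" means these few. Any claim that something is new, unique, unknown or untested is made for them only; others in the source may bear on it.

Measured compounds:
compound 1, `Clc1ccc(C2CNCCNCCNCCN2)cc1`, in a physicochemical assay for lipophilicity; a lower number here means a more polar compound, a higher number a more lipophilic compound: 0.8
compound 2, `c1ccc2cc(C3CNCCNCCNCCN3)ccc2c1`, in this assay: 1

Both numbers are close: the gap between compound 1 and compound 2 lies within the usual scatter of repeated measurements in this assay, so neither can be called the more polar of the two. Compound 3 `c1ccc(C2CNCCNCCNCCN2)cc1` has not yet been measured. It is built from compound 1 by one change: hydrogen in place of chloro on an aromatic carbon. For the measured compounds named here, no measured pair in this set shows that exact step, so the direction and size must be expected rather than read off. Taking away a chlorine atom and leaving a hydrogen in its place usually gives a smaller number in this assay, by more than the scatter. For compound 3 the estimate is 0.1, with a range from -0.4 to 0.6. That estimate means an expected downward step a number 0.70 log units lower from compound 1 to compound 3 (beyond the scatter).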

Compound 3, partition coefficient: -0.2
Compound 3: the middle estimate sits 0.30 log units above what was measured; the range from low to high includes it.
By their numbers in this assay, from the lowest: compound 3; then compounds 1 and 2 (each within the scatter of the next).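

Replacing chloro with hydrogen on an aromatic carbon, para to a large group, gives in this assay a change of a number 1.00 log units lower from compound 1 to compound 3 (beyond the scatter) for this single swap. Compound 1 and compound 2 differ in more than one place, so their numbers could not isolate any one change, whereas this pair does. At this position of the shared core, then, the loss of one chlorine atom is enough to move the number beyond the scatter.

Still open, as far as these compounds go, is where other groups at the same position would fall relative to compound 1 and compound 3, for example fluoro, bromo, a methoxy group, an amine or a carboxylic acid. Nothing measured here explains the size of this step.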